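A few compounds are considered here, and "the series" means these few. Any claim that something is new, unique, unknown or untested is made for them only; others in the source may bear on it.

Measured in an ADME assay on microsomes from liver (Rattus norvegicus) for metabolic stability; on this read-out lower numbers stand for a shorter-lived compound and higher numbers for a longer-lived compound:
- compound 1 `CC(C)C(c1ccc(-c2ccc3cccc(F)c3c2)[nH]c1=O)N1CCCCS1(=O)=O`: 0.07 h
- compound 2 `CC(C)C(Cc1ncc[nH]1)c1ccc(-c2ccc3cccc(F)c3c2)[nH]c1=O`: < 0.0667 h (a limit)
- compound 3 `CCn1ncc2c(F)cc(-c3ccc(C(CC)(CC)c4nnc[nH]4)c(=O)[nH]3)cc21`: > 3 h (a limit)

Compound 3 stands at > 3 h, which is a limit of the assay and not a number. The next analogue, compound 4 `CCn1ncc2c(F)cc(-c3ccc(C(CC)(CC)c4nncn4C)c(=O)[nH]3)cc21`, differs from it by methyl in place of hydrogen on an aromatic nitrogen.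

Among the compounds with values here, only one measured step is available, an at least 1.0-fold lower number from compound 1 to compound 2 (0.02 log units; that floor lies within the scatter). It exchanges other groups on a saturated chain carbon, so it gives no direct guide to this methyl. Compounds 1 and 2 also do not share the core of compound 3. Within the data shown here, with no measured precedent for this change, no shift beyond the scatter is expected, and the estimated step is an at least 1.2-fold lower number from compound 3 to compound 4 (0.07 log units; that floor lies within the scatter).

In this assay the estimate for compound 4 is 2.5 h, with an expected range of 0.8 h to 5 h.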

Compound 4, half-life: > 3 h
Compound 4: no number, only a limit; the forecaster's own chance of this, stated with the estimate: 40%; middle value at least 1.2-fold (0.07 log units) from the limit.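

In this assay compound 3 and compound 4 each give a limit and not a number, so no step can be read between them: the limit of > 3 h in this assay, at which 2 of the 4 values shown sit.
The compounds shown leave open how far either half-life lies past that limit, and whether methyl in place of hydrogen on the aromatic nitrogen shifts it at all.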